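The compounds below may be only part of what the source reports. "The series", "measured", "known", "first", "only" and "open" are said of these compounds alone.

Measured in a functional assay on SW-620 cells (Homo sapiens) for cytotoxicity, read by MTT assay, with stated times of 4 h and 72 h, tested at 2 uM; a higher number here means a weaker inhibitor, a lower number a stronger inhibitor:
- Compound 1 `Cc1ccc(/C=C/C(=O)c2ccc(Nc3cc(C)nc4nc(SCc5nc6ccccc6[nH]5)nn34)cc2)cc1`: 1520 nM
- Compound 2 `Cc1cc(Nc2ccc(C(=O)/C=C/c3ccc(C(F)(F)F)cc3)cc2)n2nc(SCc3nc4ccccc4[nH]3)nc2n1`: 1850 nM
- Compound 3 `Cc1cc(Nc2ccc(C(=O)/C=C/c3ccc(Cl)cc3)cc2)n2nc(SCc3nc4ccccc4[nH]3)nc2n1`: 230 nM

Compound 3 has the lowest number of the three, and its gaps to both others lie beyond the scatter. Compound 4 `Cc1cc(Nc2ccc(C(=O)/C=C/c3cccc(F)c3)cc2)n2nc(SCc3nc4ccccc4[nH]3)nc2n1` differs from compound 3 as follows: 3-fluorophenyl in place of 4-chlorophenyl on a double-bonded chain carbon bound to a double-bonded chain carbon. Among the compounds with values here, no measured compound carries the 3-fluorophenyl group, so the evidence is indirect. The closest guides are the two modest steps that reach compound 3, a 6.6-fold lower number from compound 1 to compound 3 (0.82 log units; beyond the scatter) and an 8.0-fold lower number from compound 2 to compound 3 (0.91 log units; beyond the scatter). By contrast, a 1.2-fold higher number from compound 1 to compound 2 (0.09 log units; within the scatter). Only compound 3 carries the 4-chlorophenyl group, so leaving it is expected to raise the number in this assay, though the data cannot show how far. The expected change, somewhat smaller than those two steps, is a 3.5-fold higher number from compound 3 to compound 4 (0.54 log units; beyond the scatter). For compound 4 the estimated value is 800 nM. The expected range for compound 4 runs from 250 nM to 2500 nM.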

Compound 4, half-maximal inhibitory concentration: 590 nM
Beside the measured number, compound 4's estimate is 1.4-fold (0.13 log units) above it; measured number inside the range.
By their numbers in this assay, from the lowest: compound 3; then compound 4; then compounds 1 and 2 (each within the scatter of the next).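

In this assay, the 3-fluorophenyl group gives this position a level distinct from both earlier ones, with a 2.6-fold higher number from compound 3 to compound 4 (0.41 log units; beyond the scatter), yet also a 3.1-fold lower number from compound 2 to compound 4 (0.50 log units; beyond the scatter) and a 2.6-fold lower number from compound 1 to compound 4 (0.41 log units; beyond the scatter). The position therefore no longer divides simply into 4-chlorophenyl against the rest, since a second group, carrying a different halogen at a different place on the ring, also lowers the number beyond the scatter relative to 4-methylphenyl and 4-(trifluoromethyl)phenyl, though not as far as 4-chlorophenyl does. No measurement shown here explains these differences.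

On these data alone, compound 4 changes the halogen and its place on the ring in a single step, so the share of each remains open, a question that 4-fluorophenyl and 3-chlorophenyl would address. As far as these compounds go, how an amine or a methoxy group on this ring would read also remains open.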